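Two Hydroxyls Replace an Ester on the Amide Side Chain

The source may report more compounds than this note shows. Statements on the series, on what has been measured and on what is new or still open speak of the compounds shown alone.

The shared core is kept in every compound here; only the chain on the amide-type nitrogen changes. Compound 1 `CCn1c(C(=O)NCCC(=O)OC)ccc1C(CC)(CC)c1ccc(OCS(=O)(=O)c2ccccc2)c(C)c1` carries a 2-(methoxycarbonyl)ethyl chain there. In a functional assay on MCF7 cells (Homo sapiens) for antiproliferative activity, read by MTT assay, with a stated time of 24 h (a lower number here means a stronger inhibitor, a higher number a weaker inhibitor), compound 1 gives > 50000 nM, which is a limit of the assay rather than a number. Compound 2 `CCn1c(C(=O)NCCN)ccc1C(CC)(CC)c1ccc(OCS(=O)(=O)c2ccccc2)c(C)c1` has an amino group on that chain and gives 6470 nM, while compound 3 `CCn1c(C(=O)NCCCO)ccc1C(CC)(CC)c1ccc(OCS(=O)(=O)c2ccccc2)c(C)c1` has a hydroxymethyl there and gives 42000 nM. The move from the ester to the amine is an at least 7.7-fold lower number from compound 1 to compound 2 (0.88 log units; beyond the scatter), whereas the move to the alcohol is only an at least 1.1-fold lower number from compound 1 to compound 3 (0.07 log units; that floor lies within the scatter); the two substitutes differ by a 6.5-fold higher number from compound 2 to compound 3 (0.81 log units; beyond the scatter).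

Compound 4 `CCn1c(C(=O)N[C@@H](CO)CCO)ccc1C(CC)(CC)c1ccc(OCS(=O)(=O)c2ccccc2)c(C)c1` is not yet measured. It differs from compound 1 by 3-hydroxy-1-(hydroxymethyl)propyl in place of 2-(methoxycarbonyl)ethyl on an amide-type nitrogen. Going by the values given here, the chain of compound 4 brings two hydroxyls and no amine, so the step that bears most on it is the one to compound 3, which stayed within scatter at its floor, rather than the larger one to compound 2. A small step, if any, is therefore expected in this assay, amounting to an at least 1.4-fold lower number from compound 1 to compound 4 (0.15 log units; that floor lies within the scatter). Compound 4 is estimated at 35000 nM, with a range from 12000 nM to 60000 nM, and a real chance that only a limit is reported.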

Compound 4, half-maximal inhibitory concentration: 27400 nM
For compound 4 the middle estimate is 1.3-fold (0.11 log units) above the measured one; measured number inside the range.
By their numbers in this assay, from the lowest: compound 2; then compounds 4 and 3 (each within the scatter of the next). At a limit, above all of these: compound 1.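

Putting 3-hydroxy-1-(hydroxymethyl)propyl in place of 2-(methoxycarbonyl)ethyl on the amide-type nitrogen gives an at least 1.8-fold lower number from compound 1 to compound 4 (0.26 log units; that floor lies within the scatter), a floor that does not clear the scatter, and the true size of this step stays unread since compound 1 is held only at a limit: the limit of > 50000 nM in this assay, at which 1 of the 4 values shown sits.

Going by these compounds alone, what the earlier compounds did not show is how the chain on this nitrogen responds to further hydroxyl substitution: in this assay, the hydroxymethyl on the saturated chain carbon bound to the amide-type nitrogen gives a 1.5-fold lower number from compound 3 to compound 4 (0.19 log units; within the scatter), so the two compounds cannot be told apart. The amine still stands clear of this richer alcohol chain, with a 4.2-fold higher number from compound 2 to compound 4 (0.63 log units; beyond the scatter), so among the measured compounds with a number, the 2-aminoethyl chain of compound 2 is separated from both hydroxyl-bearing chains by more than the scatter.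

The compounds shown leave open whether a carboxylic acid in place of the methyl ester, or a longer chain ending in an amine, would follow compound 2 or the alcohols. They also leave open whether the opposite configuration at the defined stereocentre of compound 4 would read the same in this assay.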